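Pyridin-3-yl for pyridin-4-yl under a shared limit

The compounds below may be only part of what the source reports. "The series", "measured", "known", "first", "only" and "open" are said of these compounds alone.

In an ADME assay on microsomes from liver (Mus musculus) for metabolic stability, read by LC-MS, using NADPH, with stated times of 15 min and 1 h, tested at 4.6 uM (on this read-out higher numbers stand for a longer-lived compound and lower numbers for a shorter-lived compound), compound 1 `NC1CCc2nc(-c3ccncc3)nc(Nc3cccc(F)c3)c2C1` gives > 1 h as its reading, which is a limit of the assay and not a number. Compound 2 `COc1cccc(Nc2nc(-c3ccncc3)nc3c2CC(N)CC3)c1` gives > 1 h as its reading, again a limit. The evidence so far is thus the limit of > 1 h in this assay, at which 2 of the 2 values shown sit, and no exact half-life stands for either compound. For the measured compounds named here, the only measured step is a step that the two limits leave unreadable from compound 1 to compound 2 and it lies at another place in the molecule than the change now in question.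

Compound 3 `NC1CCc2nc(-c3cccnc3)nc(Nc3cccc(F)c3)c2C1` has the same atoms as compound 1, joined differently: pyridin-3-yl in place of pyridin-4-yl on an aromatic carbon with pyridin-3-yl in place of pyridin-4-yl on an aromatic carbon of the shared core. Going by the values given here, no measured step covers this exchange, so no step beyond the usual scatter is expected in this assay and no direction can be given. The estimated step is a step that the limit leaves unreadable from compound 1 to compound 3 on this reckoning. Compound 3 is estimated at 1.2 h with an expected range from 0.6 h to 2.4 h and the assay may well report only a limit again.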

Compound 3, half-life: > 1 h
Compound 3 gave a limit, no number (the forecaster's own chance of this, stated with the estimate: 65%); the middle value lies beyond the limit too.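

For the compounds shown here, no step between compound 1 and compound 3 can be read in this assay because both readings are limits of the assay and not numbers: the limit of > 1 h in this assay, at which 3 of the 3 values shown sit.

The compounds shown leave open whether pyridin-3-yl and pyridin-4-yl differ at all in this assay and how far beyond the limit the half-life of each compound lies.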